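A few compounds are considered here, and "the series" means these few. Any claim that something is new, unique, unknown or untested is made for them only; others in the source may bear on it.

For the measured compounds named here, in a functional assay on PC-9 cells (Homo sapiens) for antiproliferative activity, read by MTT assay (a lower number here means a stronger inhibitor, a higher number a weaker inhibitor), compound 1 `C#CCSc1nc(Sc2nnnn2CCN(C)C)c(C#N)c(-c2cccc(Cl)c2)n1` gives 6480 nM and compound 3 `C#CCSc1nc(Sc2nnnn2CCN(C)C)c(C#N)c(-c2ccc(Cl)cc2)n1` gives 5300 nM; the step of a 1.2-fold lower number from compound 1 to compound 3 (0.09 log units; within the scatter) is the only one measured between compounds that differ in one place. Going by the values given here, compound 2 `C#CCSc1nc(Sc2nc3ccccc3s2)c(C#N)c(-c2cc(OC)c(OC)c(OC)c2)n1` stands at the limit of the assay, > 20000 nM, which is a limit and not a number; it is the single value sitting at the limit of > 20000 nM in this assay, at which 1 of the 3 values shown sits. Compound 4 `C#CCSc1nc(Sc2nc(C)c(C)s2)c(C#N)c(-c2cc(OC)c(OC)c(OC)c2)n1` differs from compound 2 by 4,5-dimethyl-1,3-thiazol-2-yl in place of 1,3-benzothiazol-2-yl on a sulfur. Among the compounds with values here, none of the measured steps touches this change, since the one recorded step concerns the chlorophenyl group and not the group on the sulfur. With compound 2 at the limit, compound 4 is expected to remain weak in this assay, the step of an at least 1.3-fold lower number from compound 2 to compound 4 (0.12 log units; that floor lies within the scatter) being an estimate only. Compound 4 is therefore estimated at 15000 nM, with a range from 4000 nM to 40000 nM.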

Compound 4, half-maximal inhibitory concentration: > 20000 nM
Compound 4 was reported as a limit; the forecaster's own chance of this, stated with the estimate: 50%; middle value at least 1.3-fold (0.12 log units) from the limit.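

Compound 2 and compound 4 both stand at a limit rather than a number in this assay, so no step can be read between them: the limit of > 20000 nM in this assay, at which 2 of the 4 values shown sit. As far as these compounds go, whether 4,5-dimethyl-1,3-thiazol-2-yl and 1,3-benzothiazol-2-yl on a sulfur differ at all stays open.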